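Nitro for Hydroxy on the Phenoxy Acetamide Side Chain

This account rests on a few compounds, and the source may have more. Where it says the series, first, only, none or still open, it means among the compounds named here.

Two compounds share a core bearing a trifluoromethyl group and a piperazine amide. Compound 1 `CC(C)C[C@H](N)c1cc(C(F)(F)F)ccc1N1CCN(C(=O)CC(C)C(=O)c2ccc(Cl)cc2)CC1` carries a 1-((4-chlorophenyl)carbonyl)ethyl group on the amide, and in an assay on HEK293 cells for displacement of a labelled ligand from Melanocortin receptor 4 (Homo sapiens) (a lower number here means a stronger inhibitor, a higher number a weaker inhibitor), compound 1 gives 1100 nM. Compound 2 `CC(C)C[C@H](N)c1cc(C(F)(F)F)ccc1N1CCN(C(=O)COc2ccc(O)cc2)CC1` has a 4-hydroxyphenoxy group in its place, and in this assay compound 2 gives 4600 nM. The step of a 4.2-fold higher number from compound 1 to compound 2 (0.62 log units; beyond the scatter) is the only one measured, so compound 2 stands at the highest of the two numbers.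

Compound 3 `CC(C)C[C@H](N)c1cc(C(F)(F)F)ccc1N1CCN(C(=O)COc2ccc([N+](=O)[O-])cc2)CC1` differs from compound 2 by nitro in place of hydroxy on an aromatic carbon. Among the compounds with values here, no measured step bears directly on this change; the step of a 4.2-fold higher number from compound 1 to compound 2 (0.62 log units; beyond the scatter) concerns the whole side chain rather than a single substituent. For compound 3 the change is therefore expected to give a step of a 1.2-fold lower number from compound 2 to compound 3 (0.06 log units; within the scatter) that lies within or close to the scatter, with no clear direction. The estimate for compound 3 in this assay is 4000 nM, with a range from 1300 nM to 12000 nM.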

Compound 3, inhibition constant: 3100 nM
For compound 3 the middle estimate is 1.3-fold (0.11 log units) above the measured one; the measured number falls inside the stated range.
By their numbers in this assay, from the lowest: compound 1; then compounds 3 and 2 (each within the scatter of the next).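

In this assay, nitro in place of hydroxy on an aromatic carbon, para to a large group, gives a 1.5-fold lower number from compound 2 to compound 3 (0.17 log units; within the scatter), so at this position the single-atom hydroxy, with its hydrogen-bond donor, and the three-atom nitro, with no donor, cannot be told apart by their numbers. The gap from the side chain of compound 1 also holds with this second substituent, at a 2.8-fold higher number from compound 1 to compound 3 (0.45 log units; beyond the scatter), so it no longer rests on the 4-hydroxyphenoxy group alone: both 4-substituted phenoxy compounds carry higher numbers than compound 1, and neither goes against this. No measurement here speaks to the reason for either step.

The compounds shown leave open whether an amine or a carboxylic acid on the same aromatic carbon would also stay within the scatter of compound 2, or whether a chlorine there would bring the number closer to that of compound 1. They also leave open how a longer chain between the amide carbonyl and the phenoxy oxygen would change the number in this assay.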